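What might replace the amino group of compound 3?

A few compounds are considered here, and "the series" means these few. Any claim that something is new, unique, unknown or untested is made for them only; others in the source may bear on it.

Of the compounds shown here, three have been measured so far in a functional assay on KB cells (nasopharynx, Homo sapiens) for antiproliferative activity; a higher number here means a weaker inhibitor, a lower number a stronger inhibitor. Compound 1 `N#Cc1c[nH]c2c(NS(=O)(=O)c3ccc(N)cc3)cccc12` gives 4.4 ug/mL, compound 2 `COc1ccc(S(=O)(=O)Nc2cccc3c(Cl)c[nH]c23)cc1` gives 0.55 ug/mL, and compound 3 `Nc1ccc(S(=O)(=O)Nc2cccc3c(Cl)c[nH]c23)cc1` gives 10 ug/mL. Compound 3 therefore has the highest number of the three, which makes it the weakest inhibitor of this small set.

The next compound, compound 4 `CNS(=O)(=O)c1ccc(S(=O)(=O)Nc2cccc3c(Cl)c[nH]c23)cc1`, has methylsulfamoyl in place of amino on an aromatic carbon, para to a large group: methylsulfamoyl in place of amino on an aromatic carbon. Two measured steps can be weighed against this change. The more relevant one is an 18-fold higher number from compound 2 to compound 3 (1.26 log units; beyond the scatter), a large step in which amino takes the place of methoxy at the same spot. The other, a 2.3-fold higher number from compound 1 to compound 3 (0.36 log units; beyond the scatter), is modest, but it swaps cyano for chloro and leaves the amino group untouched, so it says little here.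

Among the measured compounds shown here, no measured compound carries methylsulfamoyl, and a single comparison sets no rule, so the size of the step remains uncertain. Even so, the one measured alternative to amino gave a much lower number, so a sizeable move in that direction seems likely. The expected change is a 17-fold lower number from compound 3 to compound 4 (1.22 log units; beyond the scatter). For compound 4 the estimated value is 0.6 ug/mL, with an expected range from 0.12 ug/mL to 3 ug/mL.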

Compound 4, half-maximal inhibitory concentration: 15 ug/mL
Compound 4: the middle estimate sits 25-fold (1.40 log units) below what was measured; measured number outside the range, above it.
By their numbers in this assay, from the lowest: compound 2; then compound 1; then compounds 3 and 4 (each within the scatter of the next).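

In this assay, putting methylsulfamoyl where compound 3 has amino gives a 1.5-fold higher number from compound 3 to compound 4 (0.18 log units; within the scatter), so at this position, on an aromatic carbon para to a large group, the two cannot be told apart, even though the group entering has 5 heavy atoms and the one leaving has 1. Methoxy now stands alone among the three groups tried here, with a 27-fold higher number from compound 2 to compound 4 (1.44 log units; beyond the scatter) matching in scale the earlier 18-fold higher number from compound 2 to compound 3 (1.26 log units; beyond the scatter), so the low number of compound 2 no longer reads as something that follows from merely removing amino. Nothing available on these compounds accounts for this difference between methoxy and the other two groups.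

The compounds shown leave open whether the low number belongs to methoxy alone or is shared by relatives such as ethoxy, hydroxy or a plain methyl group. They also cannot say whether a chloro-to-cyano swap would matter as much with methoxy at this position as with amino, since the only cyano compound shown carries amino.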